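The compounds below may be only part of what the source reports. "The series", "measured", "known", "first", "only" and "open" are said of these compounds alone.

compound 1 `COc1ccc(NC(=O)C(=O)c2cn(C(C)C)c3c(Cl)cccc23)cn1` gives 10200 nM
compound 2 `COC(=O)CCn1cc(C(=O)C(=O)Nc2ccc(OC)nc2)c2ccccc21` gives 168 nM

In a functional assay on FaDu cells (Homo sapiens) for cytotoxicity, read by MTT assay, with a stated time of 72 h (a lower number here means that less compound is tolerated, a higher number that more compound is tolerated), compound 2 gives 168 nM as the lower of the two numbers, and compound 1 gives 10200 nM with the gap beyond the scatter. Compound 3 `COc1ccc(NC(=O)C(=O)c2cn(CCC(=O)O)c3ccccc23)cn1` differs from compound 2 by hydrogen in place of methyl on an oxygen next to a carbonyl group in that hydrogen stands in place of methyl on an oxygen next to a carbonyl group, methoxycarbonyl to carboxy. Going by the values given here, no measured pair shows this change, so the expectation is a judgement: a step to a higher number in this assay beyond the scatter. The estimated step is a 12-fold higher number from compound 2 to compound 3 (1.08 log units; beyond the scatter) as a working figure. For compound 3 the expected value is 2000 nM with an estimated range from 250 nM to 16000 nM at its ends.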

Compound 3, concentration lethal to 50% of the cells: > 10000 nM
Compound 3 gave a limit, no number (the forecaster's own chance of this, stated with the estimate: 15%); middle value at least 5.0-fold (0.69 log units) from the limit.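

Compound 3 gives > 10000 nM in this assay, which is a limit and not a number. Methoxycarbonyl to carboxy is the first change in the series read at a single place, and it gives an at least 59-fold higher number from compound 2 to compound 3 (1.77 log units; beyond the scatter), so the ester end of this chain matters in this assay. The step is bounded on one side only: the limit of > 10000 nM in this assay, at which 1 of the 3 values shown sits.

From the compounds shown here alone, how far the number rises beyond that limit stays open. Also open, going by these compounds, is whether an ethyl ester, a primary amide or a longer chain ending in methoxycarbonyl stays near compound 2 or moves towards compound 3.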